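From Hydroxy to Methylamino: One Change on Compound 1

The compounds below may be only part of what the source reports. "The series", "measured", "known", "first", "only" and "open" are said of these compounds alone.

Measured compounds:
compound 1, `COc1c(N2CC[C@@H](CO)C2)c(F)cc2c(=O)c(C(=O)O)cn(Cc3ccc(-c4ccccc4)cc3)c12`, > 200000 nM
compound 2, `COc1c(N2CC[C@@H](CN)C2)c(F)cc2c(=O)c(C(=O)O)cn(Cc3ccc4ccccc4c3)c12`, 43700 nM

In an assay on isolated protein for inhibition of DNA topoisomerase 1 (Homo sapiens), with a stated time of 15 min (a lower number here means a stronger inhibitor, a higher number a weaker inhibitor), compound 1 gives > 200000 nM; this is a limit of the assay, not a number, so compound 1 stands only at the limit of > 200000 nM in this assay, at which 1 of the 2 values shown sits. Compound 2, `COc1c(N2CC[C@@H](CN)C2)c(F)cc2c(=O)c(C(=O)O)cn(Cc3ccc4ccccc4c3)c12`, gives 43700 nM in this assay. For the measured compounds named here, compound 2 differs from compound 1 in more than one place, so the two values show only that compound 2 yields a number where compound 1 yields a limit. Compound 3, `CNC[C@@H]1CCN(c2c(F)cc3c(=O)c(C(=O)O)cn(Cc4ccc(-c5ccccc5)cc4)c3c2OC)C1`, keeps the rest of compound 1 and changes one spot: methylamino in place of hydroxy on a saturated chain carbon bound to a saturated ring carbon. Going by the values given here, the only hint on this change is that compound 2, which carries an amine of its own, gives 43700 nM as a number. The step from compound 1 to compound 3 is expected to be an at least 2.0-fold lower number from compound 1 to compound 3 (0.30 log units; that floor lies within the scatter), toward stronger inhibition, though a limit may well come back. Compound 3 is expected to give 100000 nM, with a likely range from 30000 nM to 300000 nM.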

Compound 3, half-maximal inhibitory concentration: 155000 nM
Beside the measured number, compound 3's estimate is 1.6-fold (0.19 log units) below it; measured number inside the range.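

Compound 3 differs from compound 1 in one place only, so this step isolates methylamino in place of hydroxy on a saturated chain carbon bound to a saturated ring carbon. In this assay the swap gives an at least 1.2-fold lower number from compound 1 to compound 3 (0.11 log units; that floor lies within the scatter), which means a number now stands where there was only a limit, but the printed floor of the step does not show a real gain in inhibition. Compound 1 still gives a limit and not a number, so the full size of the step cannot be read: the limit of > 200000 nM in this assay, at which 1 of the 3 values shown sits.

The compounds shown leave open how a dimethylamino group, or an ethylamino group on the same chain carbon, would read in this assay. They also leave open whether a longer chain carrying the amine would move the number clearly beyond the scatter.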